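The compounds below may be only part of what the source reports. "The series", "measured", "known", "first", "only" and "open" are said of these compounds alone.

Measured so far:
compound 1 `Nc1nc(N)nc(-c2cccc(C(F)(F)F)c2)n1` — 81%
compound 2 `Nc1nc(N)nc(-c2cccc(Cl)c2)n1` — 100%

In a functional assay on the whole organism with Rattus norvegicus as the target, at a dose of 20 mg/kg by the intraperitoneal route (on this read-out lower numbers stand for less inhibition and higher numbers for more inhibition at the one dose given (going by the name of the read-out)), compound 2 gives 100%, the higher of the two numbers in hand; compound 1 gives 81%. Compound 3 `Nc1nc(N)nc(-c2cccc(SC(F)(F)F)c2)n1` differs from compound 2 by (trifluoromethyl)sulfanyl in place of chloro on an aromatic carbon. Going by the values given here, the only measured step is a number 19 percentage points higher from compound 1 to compound 2 (beyond the scatter), trifluoromethyl giving way to chloro. The change toward compound 3 runs the other way, chloro giving way to a group that, like trifluoromethyl, carries three fluorine atoms but is larger by a sulfur. That step is not covered by any pair measured, so the trifluoromethyl-to-chloro step is the nearest guide, read in reverse. A downward step of roughly that size, or somewhat smaller, is expected, since compound 2 already sits at the top of the read-out. For compound 3 the estimate in this assay is 85%, ranging from 65% to 100%. The expected step is a number 15 percentage points lower from compound 2 to compound 3 (beyond the scatter).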

Compound 3, a percentage reported as inhibition, in the whole organism at one dose (the size of the read-out at that dose, not a potency): 87%
The estimate for compound 3 lay 2 percentage points below the measured number; the range from low to high includes it.
By their numbers in this assay, from the lowest: compounds 1 and 3 (each within the scatter of the next); then compound 2.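

In this assay, chloro now stands apart from two fluorine-bearing groups on this aromatic carbon rather than one (a number 13 percentage points lower from compound 2 to compound 3 (beyond the scatter)). The two fluorine-bearing groups are not separated by the read-out (a number 6 percentage points higher from compound 1 to compound 3 (within the scatter)), so adding sulfur to the trifluoromethyl group brings no readable change at this dose. Nothing at hand explains either step.

As far as these compounds go, whether chloro keeps its place against a group without fluorine, such as methyl, methoxy or an amine, stays open, as does the outcome of placing chloro on another carbon of the ring. A single dose gives the size of the effect and not a potency, so the standing of these compounds at other doses remains unknown.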